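Swapping a Fluoropyridine for Cyclobutyl: Stability Outlook

This account rests on a few compounds, and the source may have more. Where it says the series, first, only, none or still open, it means among the compounds named here.

Compound 1, `CS(=O)(=O)Nc1ccc2c(c1)S(=O)(=O)N=C(C1=C(O)C3CCCC3N(Cc3ccc(F)cn3)C1=O)N2`: in an in vitro ADME assay on microsomes from liver (Homo sapiens) for metabolic stability (a higher number here means that the compound lasts longer, a lower number that the compound disappears faster), compound 1 gives > 1 h, which is a limit of the assay rather than a number.
Compound 2, `CS(=O)(=O)Nc1ccc2c(c1)S(=O)(=O)N=C(C1=C(O)[C@H]3CCC[C@H]3N(Cc3ccc(F)c(F)c3)C1=O)N2`: in this assay compound 2 gives > 1 h, again a limit.

Both measured values are limits, so compound 1 stands exactly where compound 2 stands: the limit of > 1 h in this assay, at which 2 of the 2 values shown sit. Within the data shown here, nothing separates the two, and no step between them can be read off.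

Compound 3, `CS(=O)(=O)Nc1ccc2c(c1)S(=O)(=O)N=C(C1=C(O)C3CCCC3N(CC3CCC3)C1=O)N2`, is the compound still to be measured. It differs from compound 1 in one place: cyclobutyl in place of 5-fluoropyridin-2-yl on a saturated chain carbon bound to an amide-type nitrogen in a ring. Among the measured compounds shown here, no measured step spans a change of this kind, so any expectation rests on the two limits alone. Compound 1 sits at the limit (the limit of > 1 h in this assay, at which 2 of the 2 values shown sit), and a measured number for compound 3 could fall at or short of it. The step of an at least 1.1-fold lower number from compound 1 to compound 3 (0.04 log units; that floor lies within the scatter) is expected to be modest and, if anything, downward, quite possibly within the scatter. Compound 3 is therefore estimated at 0.9 h, within a range from 0.4 h to 2 h, with a fair chance that the assay again reports only a limit.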

Compound 3, half-life: 0.0667 h
For compound 3 the middle estimate is 13-fold (1.13 log units) above the measured one; measured number below the stated range.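

Putting cyclobutyl in place of 5-fluoropyridin-2-yl on a saturated chain carbon bound to an amide-type nitrogen in a ring gives an at least 14-fold lower number from compound 1 to compound 3 (1.17 log units; beyond the scatter) in this assay, so the group at this position can by itself bring a compound well away from the limit. Among these compounds, the earlier compounds gave no sign of this sensitivity, as their only readings were one shared limit: the limit of > 1 h in this assay, at which 2 of the 3 values shown sit. The size of the step is a floor rather than an exact figure: compound 1 gives > 1 h, which is a limit and not a number.

This single change removes an aromatic ring with its nitrogen and its fluorine and brings in a smaller, non-aromatic carbon ring, so the compounds shown cannot tell which of these differences accounts for the step. A plain phenyl, a cyclohexyl or an oxetane ring on the same saturated chain carbon, each compared directly with compound 1 and compound 3, would begin to separate ring size, aromatic character and the ring's hetero atoms.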